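Swapping a Methylsulfonyl for a Carbamoyl Group

The source may hold more compounds than are shown below. What is called first, only, known or untested is meant among the compounds shown, and "the series" means these compounds.

Measured so far:
compound 1 `COc1ccc(-c2cc(-c3cccc(S(C)(=O)=O)c3)cnc2N)cn1` gives 2.3 in a physicochemical assay for lipophilicity, at pH 7.4; a higher number here means a more lipophilic compound, a lower number a more polar compound;
compound 2 `COc1ccc(-c2cc(-c3ccc(S(C)(=O)=O)c(F)c3)cnc2N)cn1` gives 2.5 in this assay.

For the measured compounds named here, only two compounds have been measured, and they share the same core. In this assay compound 1 gives 2.3, while compound 2 gives 2.5; the two numbers sit close together, within the usual scatter of repeated measurements, so nothing separates them with confidence. Compound 1 is the starting point for the next change.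

Compound 3 `COc1ccc(-c2cc(-c3cccc(C(N)=O)c3)cnc2N)cn1` has not been measured. It differs from compound 1 by carbamoyl in place of methylsulfonyl on an aromatic carbon, in words: carbamoyl in place of methylsulfonyl on an aromatic carbon. Going by the values given here, no pair of measured compounds shows this particular exchange, so there is no measured step to lean on. Both groups are uncharged and small, and the exchange leaves the rest of the molecule untouched, so the expected step from compound 1 to compound 3 is small, a number 0.10 log units lower from compound 1 to compound 3 (within the scatter), and is not expected to exceed the scatter. On that basis compound 3 is expected to give 2.2 in this assay, with a plausible range from 1.6 to 2.8.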

Compound 3, distribution coefficient: 1.7
Compound 3: middle estimate off by 0.50 log units, on the high side; low and high end bracket the measured number.
By their numbers in this assay, from the lowest: compound 3; then compounds 1 and 2 (each within the scatter of the next).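

For the compounds shown here, this is the first step that stands clear of the scatter: in this assay, carbamoyl in place of methylsulfonyl on an aromatic carbon gives a number 0.60 log units lower from compound 1 to compound 3 (beyond the scatter). The place on the ring, meta to a large group, is therefore one where the number responds to a change of a single group, even though both groups carry no net charge and the rest of the molecule stays the same. The exchange alters several counted features at once, with one heavy atom fewer, one double bond fewer and a hydrogen-bond donor gained, and no measurement here bears on which of them accounts for the step.

The compounds shown leave open where a nitrile, an amine or a carboxylic acid at this same place would fall in this assay. They also leave open whether the same exchange made on compound 2, which carries a fluorine and has its methylsulfonyl elsewhere on the ring, would give a step of similar size.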